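Swapping Trifluoromethyl for Methoxy and the Resulting Half-Life

The source may report more compounds than this note shows. Statements on the series, on what has been measured and on what is new or still open speak of the compounds shown alone.

Three measured compounds are compared here. In a physicochemical assay for pharmacokinetics, at pH 6 (on this read-out higher numbers stand for a longer-lived compound and lower numbers for a shorter-lived compound), compound 1 `O=C(Sc1cccnc1C(=O)O)c1cccc(C(F)(F)F)c1` gives 3.9 h and compound 3 `COc1cccc(C(=O)Sc2cccnc2C(=O)O)c1` gives 11.9 h. The change between them, (methoxy in place of trifluoromethyl on an aromatic carbon), made a 3.1-fold higher number from compound 1 to compound 3 (0.48 log units; beyond the scatter). Compound 2 `O=C(Sc1cccnc1C(=O)O)c1ccc(C(F)(F)F)cc1` gives 3 h in this assay; how its core differs from the core of compound 1 is not broken down here. Compound 4 `COc1ccc(C(=O)Sc2cccnc2C(=O)O)cc1` carries the same kind of change relative to compound 2, namely (methoxy in place of trifluoromethyl on an aromatic carbon), but there the new group sits para to a large group, whereas in compound 3 it sits meta to a large group. The step expected here is a 3.0-fold higher number from compound 2 to compound 4 (0.48 log units; beyond the scatter), resting on the earlier 3.1-fold higher number from compound 1 to compound 3 (0.48 log units; beyond the scatter). Compound 4 is therefore estimated at 9 h, with a likely range from 4.5 h to 18 h.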

Compound 4, half-life: 43.9 h
Compound 4: the middle estimate sits 4.9-fold (0.69 log units) below what was measured; the whole stated range lies below it.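

In this assay the same swap of trifluoromethyl for methoxy gave a 15-fold higher number from compound 2 to compound 4 (1.17 log units; beyond the scatter) and the earlier 3.1-fold higher number from compound 1 to compound 3 (0.48 log units; beyond the scatter) so the direction carried from one core to the other, while the size of the step did not. In compound 4 the methoxy sits para to a large group, and two pairs cannot show whether a rise of this size would recur on any further core. Nothing measured here bears on why the two steps differ in size.

The compounds shown leave open how far this rise belongs to methoxy itself. An amine or a longer chain such as ethoxy on the same aromatic carbon could tell whether other groups follow it.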